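The compounds below may be only part of what the source reports. "The series", "measured", "known", "first", "only" and "open" are said of these compounds alone.

Measured so far:
Compound 1, `O=S(=O)(NCCCNCC1COc2ccccc2O1)c1cc(C(F)(F)F)cc(C(F)(F)F)c1`, in a functional assay on HT-29 cells (Homo sapiens) for inhibition, read by MTT assay, with a stated time of 72 h (a higher number here means a weaker inhibitor of growth, a lower number a stronger inhibitor of growth), compound 1 gives 2200 nM.
Compound 2, `CN(CCCNS(=O)(=O)c1cc(C(F)(F)F)cc(C(F)(F)F)c1)Cc1ccccc1`, in this assay compound 2 gives > 50000 nM.

In this assay compound 1 has a measured number. For compound 2, by contrast, the result is only a limit of the assay, > 50000 nM, and not a number. This is the limit of > 50000 nM in this assay, at which 1 of the 2 values shown sits; of the two values shown, compound 2 is the one that sits at that limit. Among the measured compounds shown here, no step between two measured compounds is recorded here, since compounds 1 and 2 differ in more than one place, so only their two values can be compared, and compound 1 is the one with a measured number.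

Compound 3, `COc1ccccc1CNCCCNS(=O)(=O)c1cc(C(F)(F)F)cc(C(F)(F)F)c1`, is not yet measured. It differs from compound 2 by (2-methoxybenzyl)amino in place of benzyl(methyl)amino on a saturated chain carbon, three bonds along the chain from a sulfonamide nitrogen. The change brings in one hydrogen-bond donor and a second hydrogen-bond acceptor where compound 2 has none and one. Given that compound 2 gives only a limit, any measured number for compound 3 would already be a step toward stronger inhibition of growth. Compound 3 is expected to move by about an at least 8.3-fold lower number from compound 2 to compound 3 (0.92 log units; beyond the scatter), in the direction of stronger inhibition of growth, well beyond the usual scatter. The estimate for compound 3 in this assay is 6000 nM, with a range from 1500 nM to 30000 nM.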

Compound 3, concentration for 50% growth inhibition: 12000 nM
For compound 3 the middle estimate is 2.0-fold (0.30 log units) below the measured one; low and high end bracket the measured number.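

In this assay, (2-methoxybenzyl)amino in place of benzyl(methyl)amino on the saturated chain carbon gives an at least 4.1-fold lower number from compound 2 to compound 3 (0.61 log units; beyond the scatter), the first sign that growth inhibition at this end of the chain responds to a change within a benzylamine-type group. Among the compounds shown here, for compound 2 the result is a limit of the assay and not a number, so this step fixes only a minimum size: the limit of > 50000 nM in this assay, at which 1 of the 3 values shown sits. Compound 3 also allows the first one-place comparison with compound 1: 2-methoxyphenyl in place of 2,3-dihydro-1,4-benzodioxin-2-yl gives a 5.5-fold higher number from compound 1 to compound 3 (0.74 log units; beyond the scatter), so the group carried by compound 1 remains the better of the two at this place.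

The step from compound 2 to compound 3 joins two changes, the loss of the methyl on the amine nitrogen and the gain of the methoxy on the ring, and the compounds shown cannot separate them. Plain benzylamino would show what the amine hydrogen contributes without the methoxy, and a 3-methoxybenzyl or 4-methoxybenzyl amine would show whether the place of the methoxy on the ring matters.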